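Cyanoguanidines on rat aorta: from isopropyl to cyclopentyl

This account rests on a few compounds, and the source may have more. Where it says the series, first, only, none or still open, it means among the compounds named here.

compound 1 `CC(C)/N=C(\NC#N)Nc1cc(C(F)(F)F)cc(C(F)(F)F)c1`: 61000 nM
compound 2 `CCC(C)(C)/N=C(\NC#N)Nc1cc(C(F)(F)F)cc(C(F)(F)F)c1`: 900 nM

Of the two measured compounds, compound 1 gives the highest number, 61000 nM in a functional assay (aorta) with Rattus norvegicus as the target; on this read-out higher numbers stand for weaker inhibition and lower numbers for stronger inhibition; compound 2 gives 900 nM. For the measured compounds named here, the one measured step, a 68-fold lower number from compound 1 to compound 2 (1.83 log units; beyond the scatter), is large. Compound 3 `N#CN/C(=N\C1CCCC1)Nc1cc(C(F)(F)F)cc(C(F)(F)F)c1` differs from compound 1 by cyclopentyl in place of isopropyl on a double-bonded nitrogen. Going by the values given here, only that step bears on it, and in both changes the group on the double-bonded nitrogen gains carbon, so a large drop in this assay is expected, though no cyclopentyl has been measured here. Compound 3 is therefore expected at 3000 nM, between 500 nM and 20000 nM, an estimated step of a 20-fold lower number from compound 1 to compound 3 (1.31 log units; beyond the scatter).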

Compound 3, half-maximal inhibitory concentration: > 300000 nM
Compound 3 ended at the assay's limit; the forecaster's own chance of this, stated with the estimate: 5%; at least 100-fold (2.00 log units) between middle value and limit.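

Compound 3 gives > 300000 nM, which is a limit of this assay and not a number. On the double-bonded nitrogen, gaining carbon does not by itself give a lower number: cyclopentyl brings an at least 4.9-fold higher number from compound 1 to compound 3 (0.69 log units; beyond the scatter), and the comparison with the open chain brings an at least 330-fold higher number from compound 2 to compound 3 (2.52 log units; beyond the scatter). Both steps are minimum sizes: the limit of > 300000 nM in this assay, at which 1 of the 3 values shown sits.

Still open, going by these compounds, is whether cyclobutyl or cyclohexyl at this place would behave like cyclopentyl. A longer open chain such as pentyl might instead follow compound 2.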